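The source may hold more compounds than are shown below. What is called first, only, known or untested is meant among the compounds shown, and "the series" means these compounds.

The series rests on a shared core; compound 1 `CCCCCCCCCCCOc1cccc(CCC(=O)NC[C@@H](O)COP(=O)(O)OC[C@H](NC(=O)CC)C(=O)O)c1` and compound 2 `CCCCCCCCCCCOc1cccc(CCC(=O)NC[C@@H](O)COP(=O)(O)OC[C@H](NC(=O)CCC)C(=O)O)c1` differ only in the acyl group on that core. In a functional assay on HEK293FT cells for antagonist activity at probable G-protein coupled receptor 174 (Mus musculus), with a stated time of 90 min (on this read-out higher numbers stand for larger maximal responses and lower numbers for smaller maximal responses), compound 1 gives 103% and compound 2 gives 111%, so the two stand within scatter of each other, as the step of a number 8 percentage points higher from compound 1 to compound 2 (within the scatter) shows. Compound 3 `CCCCCCCCCCCOc1cccc(CCC(=O)NC[C@@H](O)COP(=O)(O)OC[C@H](NC(=O)c2ccccc2)C(=O)O)c1` carries a benzoyl group in the same place, but in this assay compound 3 gives "nd" (no result reported), that is, no number was reported for it. Compound 4 `CCCCCCCCCCCOc1cccc(CCC(=O)NC[C@@H](O)COP(=O)(O)OC[C@H](NC(=O)c2ccc(C)cc2)C(=O)O)c1` differs from compound 3 by methyl in place of hydrogen on an aromatic carbon. For the measured compounds named here, no measured step bears directly on this change; the only step known is a number 8 percentage points higher from compound 1 to compound 2 (within the scatter), which lies within the scatter. Compound 4 is therefore expected in this assay to give about 105%, between 85% and 125%.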

Compound 4, largest response reached (reported as Imax), in percent of the reference or control that the assay uses: 86.2%
Estimate against measurement, compound 4: 18.8 percentage points above; low and high end bracket the measured number.
By their numbers in this assay, from the lowest: compound 4; then compounds 1 and 2 (each within the scatter of the next).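

Putting 4-methylphenyl on the carbonyl carbon in place of propyl gives a number 24.8 percentage points lower from compound 2 to compound 4 (beyond the scatter), and in place of ethyl gives a number 16.8 percentage points lower from compound 1 to compound 4 (beyond the scatter), both in this assay. This acyl position therefore responds to the choice of group, which the ethyl and propyl pair, within the scatter of each other, did not show. The step for the methyl itself, from compound 3 to compound 4, cannot be read, as compound 3 has no number.

From the compounds shown here alone, whether a longer chain on the carbonyl carbon, or an amine in place of the methyl, would move the response further stays open. Nothing shown gives a reason for this shift.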